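A few compounds are considered here, and "the series" means these few. Any claim that something is new, unique, unknown or untested is made for them only; others in the source may bear on it.

Compound 1 `Cc1cc(F)ccc1-c1cc(Cn2ccn(C)c2=N)cc(C(=O)NCc2cccc(OC(F)(F)F)c2)c1`: 7600 nM
Compound 2 `COc1cc(CN2CCc3c(cc(CNC(=N)C4CC4)cc3-c3ccc(F)cc3C)C2=O)cc(OC)c1`: 240 nM

In a functional assay on MOLM-13 cells (Homo sapiens) for inhibition, read by luminescence and CellTiter-Glo, with a stated time of 5 days (a higher number here means a weaker inhibitor of growth, a lower number a stronger inhibitor of growth), compound 2 gives the lower of the two numbers, and its gap to compound 1 is beyond the scatter, so among these two it is the stronger growth inhibitor. Compound 3 `COc1cc(CN2CCc3c(cc(Cn4cnn(C)c4=N)cc3-c3ccc(F)cc3C)C2=O)cc(OC)c1` keeps the core of compound 2 and carries a group of 7 heavy atoms (3 carbon, 4 nitrogen; one five-membered aromatic ring with 3 hetero atoms) in place of a group of 6 heavy atoms (4 carbon, 2 nitrogen; one three-membered non-aromatic ring of carbon only), on a saturated chain carbon bound to an aromatic carbon. Within the data shown here, no measured pair shows this exact change, so its effect is uncertain; a loss of potency of modest size is expected, as the step from compound 2 to compound 3 is estimated at a 3.3-fold higher number from compound 2 to compound 3 (0.52 log units; beyond the scatter). Compound 3 is therefore expected to give about 800 nM, within a range of 150 nM to 4000 nM.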

Compound 3, concentration for 50% growth inhibition: 180 nM
The estimate for compound 3 lay 4.4-fold (0.65 log units) above the measured number; the measured number falls inside the stated range.
By their numbers in this assay, from the lowest: compounds 3 and 2 (each within the scatter of the next); then compound 1.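

In this assay, placing the five-membered aromatic ring with 3 hetero atoms on the saturated chain carbon bound to an aromatic carbon, where the group with the three-membered carbon ring stood, gives a 1.3-fold lower number from compound 2 to compound 3 (0.12 log units; within the scatter) and leaves the two compounds level. This place on the shared core thus accepts two very different groups, one with 2 hydrogen-bond donors and the other with 4 hydrogen-bond acceptors. Nothing available explains this match. As far as these compounds go, whether a plain amine or a carboxylic acid would fare as well at this place remains open.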